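Stability series: compound 1 to compound 4

A few compounds are considered here, and "the series" means these few. Any claim that something is new, unique, unknown or untested is made for them only; others in the source may bear on it.

Compound 1 `c1ccc2c(c1)CN[C@@H](CN(CC1CCNCC1)[C@H]1CCCc3cccnc31)C2` heads the set in an ADME assay on microsomes from liver (Homo sapiens) for metabolic stability, read by LC-MS, with a stated time of 10 min, tested at 0.5 uM (on this read-out higher numbers stand for a more stable compound and lower numbers for a less stable compound), giving 86%. Compound 3 `c1cnc2c(c1)CCC[C@@H]2N(CCCN1CCNCC1)Cc1nc2ccccc2[nH]1` stands nearest with 63%, and compound 2 `c1cnc2c(c1)CCC[C@@H]2N(CCCN1CCNCC1)Cc1nc2ccccc2s1` furthest with 50%; compound 1 sits above both by margins beyond the scatter. Within the data shown here, the only measured step, a number 13 percentage points higher from compound 2 to compound 3 (beyond the scatter), concerns a change at a different part of the molecule and does not bear on the present one. Compound 4 `CC(C)N1CCN(CCCN(C[C@H]2Cc3ccccc3CN2)[C@H]2CCCc3cccnc32)CC1` differs from compound 1 by 2-(4-isopropylpiperazin-1-yl)ethyl in place of piperidin-4-yl on a saturated chain carbon bound to an amine nitrogen. Among the measured compounds shown here, no measured pair isolates this change, so the expectation rests on the values themselves: the two compounds carrying a longer basic chain at this position, compound 2 and compound 3, both sit well under compound 1, though each also differs elsewhere. A modest downward step in this assay is therefore expected, not a flat one. Compound 4 is expected to give 70%, with a range of 50% to 88%. The expected step is a number 16 percentage points lower from compound 1 to compound 4 (beyond the scatter).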

Compound 4, percent of the compound remaining: 46%
Compound 4: the middle estimate sits 24 percentage points above what was measured; the whole stated range lies above it.
By their numbers in this assay, from the lowest: compounds 4 and 2 (each within the scatter of the next); then compound 3; then compound 1.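

In this assay, 2-(4-isopropylpiperazin-1-yl)ethyl in place of piperidin-4-yl on a saturated chain carbon bound to an amine nitrogen gives a number 40 percentage points lower from compound 1 to compound 4 (beyond the scatter) and so shows that stability at this position depends strongly on the group carried there. Compound 2 and compound 3 could not show this, as each differs from compound 1 in more than one place, whereas here the rest of the molecule stays the same. No measurement at hand accounts for the size of the step.

On these data alone, the change replaces the ring, adds the ethyl link and adds the isopropyl group all at once, so the share of each in the step stays open. A methyl group in place of the isopropyl, or a morpholine ring in place of the piperazine, would begin to separate these contributions.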